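A few compounds are considered here, and "the series" means these few. Any claim that something is new, unique, unknown or untested is made for them only; others in the source may bear on it.

In a functional assay on MDA-MB-231 cells (Homo sapiens) for antiproliferative activity, read by MTT assay, with a stated time of 72 h (on this read-out lower numbers stand for stronger inhibition of growth and higher numbers for weaker inhibition of growth), three compounds built on a shared core have been tested so far. Compound 1 (`O=[N+]([O-])c1ccc(-c2nss/c2=N\c2ccccc2)cc1`) gives > 10000 nM, which is a limit of the assay and not a number. Compound 2 (`Fc1ccc(-c2nss/c2=N\c2ccccc2)cc1`) gives > 10000 nM, again a limit. Compound 3 (`c1ccc(/N=c2\ssnc2-c2ccco2)cc1`) gives > 10000 nM, also a limit. Compound 3 therefore has no exact value, and it cannot be ranked against the other two. The whole set so far is summed up as the limit of > 10000 nM in this assay, at which 3 of the 3 values shown sit.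

Compound 4 (`CCOC(=O)c1nss/c1=N\c1ccccc1`) changes compound 3 in one place: ethoxycarbonyl in place of furan-2-yl on an aromatic carbon, (ethoxycarbonyl in place of furan-2-yl on an aromatic carbon). The ring-bearing group leaves, and an open group with the same count of heavy atoms enters.

Going by the values given here, only one measured step exists for comparison, a step that the two limits leave unreadable from compound 1 to compound 2. It is a different swap at a different group, and it gives no size to carry over. With no readable step and no direction to draw on, the expectation in this assay is for no change beyond the scatter, with compound 4 most likely reported as a limit too. The expected outcome is a step that the limit leaves unreadable from compound 3 to compound 4. For compound 4 the estimated value is 12000 nM, with an expected range from 3000 nM to 40000 nM.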

Compound 4, concentration for 50% growth inhibition: > 10000 nM
Compound 4: only a limit was reported (the forecaster's own chance of this, stated with the estimate: 70%); the middle value lies beyond the limit too.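

No size can be read for the swap from compound 3 to compound 4, because both give only a limit of the assay and not a number: the limit of > 10000 nM in this assay, at which 4 of the 4 values shown sit.

The compounds shown leave open how far apart these four really lie, and whether any group on the shared core would give a measurable value in this assay.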